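The source may hold more compounds than are shown below. What is called first, only, known or untested is meant among the compounds shown, and "the series" means these compounds.

Notes on the series. Compound 1 `Nc1sc(-c2ccc(Cl)cc2)c(-c2ccc(Cl)cc2)c1C(=O)N1CCCC1` gives 6220 nM in a functional assay on PC-3 cells (Homo sapiens) for inhibition, read by sulforhodamine B assay, with a stated time of 72 h; on this read-out lower numbers stand for stronger inhibition and higher numbers for weaker inhibition; compound 2 `Nc1sc(-c2ccc(Cl)cc2)c(-c2ccc(Cl)cc2)c1C(=O)NC1CCCCC1` gives 7300 nM in this assay; compound 3 `Nc1sc(-c2ccc(Cl)cc2)c(-c2ccc(Cl)cc2)c1C(=O)NCc1ccccc1` gives 31800 nM in this assay, the highest of the three numbers. Within the measured set, a 1.2-fold higher number from compound 1 to compound 2 (0.07 log units; within the scatter), a 5.1-fold higher number from compound 1 to compound 3 (0.71 log units; beyond the scatter) and a 4.4-fold higher number from compound 2 to compound 3 (0.64 log units; beyond the scatter). Compound 4 `Nc1sc(-c2ccc(Cl)cc2)c(-c2ccc(Cl)cc2)c1C(=O)NC1CCCC1` differs from compound 3 by cyclopentyl in place of benzyl on an amide-type nitrogen. The step from compound 2 to compound 3 runs the same kind of exchange in the opposite direction, with cyclohexyl rather than cyclopentyl, and the step from compound 1 to compound 3 points the same way, so a lower number in this assay for compound 4 is expected, of roughly that size. For compound 4 an expected change of a 4.2-fold lower number from compound 3 to compound 4 (0.63 log units; beyond the scatter) in this assay gives an estimate of 7500 nM, with a range of 3500 nM to 16000 nM.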

Compound 4, half-maximal inhibitory concentration: 21200 nM
Estimate against measurement, compound 4: 2.8-fold (0.45 log units) below, and the stated range ends below it.
By their numbers in this assay, from the lowest: compounds 1 and 2 (each within the scatter of the next); then compounds 4 and 3 (each within the scatter of the next).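

Cyclopentyl and benzyl on the amide-type nitrogen stay within the scatter of each other in this assay (a 1.5-fold lower number from compound 3 to compound 4 (0.18 log units; within the scatter)), so the gap between cyclohexyl and benzyl does not extend to every non-aromatic ring at this place. Cyclopentyl and cyclohexyl are not interchangeable here (a 2.9-fold higher number from compound 2 to compound 4 (0.46 log units; beyond the scatter)), and cyclopentylamino also separates from pyrrolidin-1-yl on the carbonyl carbon (a 3.4-fold higher number from compound 1 to compound 4 (0.53 log units; beyond the scatter)). Nothing available explains these differences. Still open, from the compounds shown here alone, is whether a longer alkyl chain on this nitrogen, or a cyclohexyl ring carrying an amine or a carboxylic acid, would shift the number.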